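The source may report more compounds than this note shows. Statements on the series, on what has been measured and on what is new or still open speak of the compounds shown alone.

Measured so far:
compound 1, `Nc1cccc(/C=C2\SC(=O)N(Cc3cccc(F)c3)C2=O)c1` — 250000 nM
compound 2, `Nc1ccc(/C=C2\SC(=O)N(Cc3cccc(F)c3)C2=O)cc1` — 116000 nM

In a functional assay on CCRF-CEM cells (Homo sapiens) for cytotoxicity, read by cell counting, with a stated time of 3 days (on this read-out higher numbers stand for weaker inhibition and lower numbers for stronger inhibition), compound 1 stands at the highest of the two numbers; the nearest is compound 2, with a 2.2-fold lower number from compound 1 to compound 2 (0.33 log units; beyond the scatter). Compound 3, `Nc1cccc(/C=C2\SC(=O)N(Cc3ccccc3)C2=O)c1`, differs from compound 1 by hydrogen in place of fluoro on an aromatic carbon. Going by the values given here, the one measured step concerns a different part of the shared core and does not bear on this change. Among the compounds with values here, with no step to draw on, no shift beyond the scatter is expected in this assay, so compound 3 is estimated at 250000 nM (range 100000 nM to 600000 nM), which means an expected step of no change at the digits printed from compound 1 to compound 3 (within the scatter).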

Compound 3, half-maximal inhibitory concentration: > 250000 nM
Compound 3 gave a limit, no number; the forecaster's own chance of this, stated with the estimate: 25%; the middle value lies on the limit itself.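

Compound 3 gives a limit of the assay, not a number: > 250000 nM. In this assay, going by these compounds alone, hydrogen in place of fluoro on this aromatic carbon brings a number no lower from compound 1 to compound 3 (the limit leaves the size open), which is the first reading on this part of the shared core, though the size of the step cannot be read. The result stands at the edge of what the assay reports: the limit of > 250000 nM in this assay, at which 1 of the 3 values shown sits.

Still open, from the compounds shown here alone, is how a chloro, methoxy or carboxylic acid group would read on this aromatic carbon. Also open, going by these compounds, is how the same change would read on compound 2.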